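The source may hold more compounds than are shown below. What is called first, only, known or untested is meant among the compounds shown, and "the series" means these compounds.

Four compounds are compared in an ADME assay on Vero cells (Chlorocebus sabaeus) for cytotoxicity, with a stated time of 72 h; a higher number here means a weaker inhibitor, a lower number a stronger inhibitor. Compound 1 `N#Cc1ccc(-c2ccc(CO[C@@H]3COc4nc([N+](=O)[O-])cn4C3)s2)cc1` and compound 2 `O=[N+]([O-])c1cn2c(n1)OC[C@@H](OCc1ccc(-c3ccc(F)cc3)s1)C2` share one core, while compound 3 `N#Cc1ccc(-c2cc(CO[C@@H]3COc4nc([N+](=O)[O-])cn4C3)on2)cc1` and compound 4 `O=[N+]([O-])c1cn2c(n1)OC[C@@H](OCc1cc(-c3ccc(F)cc3)no1)C2` share another; the difference between the two cores is not broken down here. In this assay compound 1 gives only a limit, > 128000 nM. Compound 2 also gives only a limit, > 128000 nM. Compound 3 likewise gives only a limit, > 128000 nM. The change from compound 1 to compound 2 is fluoro in place of cyano on an aromatic carbon, and its step in this assay reads as a step that the two limits leave unreadable from compound 1 to compound 2 because the limit of > 128000 nM in this assay, at which 3 of the 3 values shown sit, hides how large it really is. Compound 4 differs from compound 3 by fluoro in place of cyano on an aromatic carbon, the same change at the same place. The expectation for compound 4 therefore rests on the limit seen for compound 3 together with the unreadable step that the two limits leave unreadable from compound 1 to compound 2 between compound 1 and compound 2. The step from compound 3 to compound 4 is expected to be a step that the limit leaves unreadable from compound 3 to compound 4, in other words not distinguishable from no change. Compound 4 is expected to give 200000 nM in this assay, most likely again as a limit, with a range estimated from 100000 nM to 400000 nM.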

Compound 4, half-maximal inhibitory concentration: > 128000 nM
Compound 4 gave a limit, no number; the forecaster's own chance of this, stated with the estimate: 85%; the middle value lies beyond the limit too.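

In this assay no size can be read for the step from compound 3 to compound 4, because both compounds give only a limit, as do compound 1 and compound 2: the limit of > 128000 nM in this assay, at which 4 of the 4 values shown sit. The compounds shown leave open at what concentration any of them would become toxic to these cells, and whether 4-cyanophenyl and 4-fluorophenyl differ at all here.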